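Swapping a Furan for a Dimethylphenyl on a Shared Core

The source may hold more compounds than are shown below. What is called first, only, known or untested is meant among the compounds shown, and "the series" means these compounds.

Three compounds share one core and differ only in the group attached to a carbon with a double bond to nitrogen. Compound 1 `Cn1c(=O)c(=O)n(C2CCCC2)c2nc(N/N=C/c3ccccc3)ncc21` carries a phenyl there and gives 48200 nM in a functional assay on PC-3 cells (Homo sapiens) for antiproliferative activity, read by MTT assay; on this read-out higher numbers stand for weaker inhibition and lower numbers for stronger inhibition. Compound 2 `Cn1c(=O)c(=O)n(C2CCCC2)c2nc(N/N=C/c3ccc(S(C)(=O)=O)cc3)ncc21` carries a 4-(methylsulfonyl)phenyl and gives 26600 nM in this assay. Compound 3 `Cn1c(=O)c(=O)n(C2CCCC2)c2nc(N/N=C/c3ccco3)ncc21` carries a furan-2-yl and gives 72200 nM in this assay. Its number is the highest of the three, a standing that rests on a 2.7-fold higher number from compound 2 to compound 3 (0.43 log units; beyond the scatter) being beyond the scatter, whereas a 1.5-fold higher number from compound 1 to compound 3 (0.18 log units; within the scatter) stays within it.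

Compound 4 `Cc1ccc(/C=N/Nc2ncc3c(n2)n(C2CCCC2)c(=O)c(=O)n3C)cc1C` has not yet been measured. It differs from compound 3 by 3,4-dimethylphenyl in place of furan-2-yl on a carbon with a double bond to nitrogen. For the measured compounds named here, two measured steps bear on this exchange of one aromatic ring for another at the same place: a 1.5-fold higher number from compound 1 to compound 3 (0.18 log units; within the scatter) and a 2.7-fold higher number from compound 2 to compound 3 (0.43 log units; beyond the scatter). Both run from a six-membered ring of carbon to the furan and both raise the number, though only the second lies beyond the scatter. Reversing that direction, a six-membered ring of carbon in place of the furan is expected to lower the number somewhat, landing near compound 1. Compound 4 is therefore estimated at about 40000 nM, within a range from 15000 nM to 100000 nM. The expected step is a 1.8-fold lower number from compound 3 to compound 4 (0.26 log units; within the scatter).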

Compound 4, half-maximal inhibitory concentration: 39000 nM
Compound 4: the middle estimate sits 1.0-fold (0.01 log units) above what was measured; the measured number falls inside the stated range.
By their numbers in this assay, from the lowest: compounds 2, 4, 1 and 3 (each within the scatter of the next, the first and the last beyond it).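

At the carbon with a double bond to nitrogen, 3,4-dimethylphenyl in place of furan-2-yl gives, in this assay, a 1.9-fold lower number from compound 3 to compound 4 (0.27 log units; within the scatter) and so stays inside the scatter, as does the change from plain phenyl, with a 1.2-fold lower number from compound 1 to compound 4 (0.09 log units; within the scatter), which means the two added methyl groups make no readable difference here. For the compounds shown here, the comparison with the methylsulfonyl-bearing ring reads the same way, with a 1.5-fold higher number from compound 2 to compound 4 (0.17 log units; within the scatter), so compound 4 lies within the scatter of all three earlier compounds and bridges compound 2 and compound 3, the one pair that remains apart beyond the scatter. No measured property of these groups is available to account for how close the four numbers lie.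

On these data alone, all four compounds carry an aromatic ring at this place, so it remains open whether a ring bearing an amine or a carboxylic acid, or a longer alkyl chain in place of the ring, would move the number clearly outside the span set by compound 2 and compound 3. As far as these compounds go, the shared core is the same throughout, so what a change there would do also remains open.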